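A few compounds are considered here, and "the series" means these few. Any claim that something is new, unique, unknown or untested is made for them only; others in the source may bear on it.

Measured compounds in a functional assay on MCF7 cells (Homo sapiens) for cytotoxicity, read by MTT assay, with a stated time of 72 h; a lower number here means a stronger inhibitor, a higher number a weaker inhibitor:
Compound 1 `FC(F)(F)c1ccc(CSc2nc(Nc3ccccc3C(F)(F)F)c3ccccc3n2)cc1` gives > 50000 nM, which is a limit of the assay rather than a number.
Compound 2 `Cc1ccccc1Nc1nc(SCc2ccc(C(F)(F)F)cc2)nc2ccccc12` gives 37500 nM.
Compound 3 `FC(F)(F)c1ccc(CSc2nc(Nc3ccc(C(F)(F)F)cc3)c3ccccc3n2)cc1` gives 5100 nM.

The cores of compound 1 and compound 3 differ as 4-(trifluoromethyl)phenyl in place of 2-(trifluoromethyl)phenyl on a nitrogen on an aromatic ring; that change gives an at least 9.8-fold lower number from compound 1 to compound 3 (0.99 log units; beyond the scatter), and from compound 2 the related step is a 7.4-fold lower number from compound 2 to compound 3 (0.87 log units; beyond the scatter). Compound 4 `Cc1ccc(Nc2nc(SCc3ccc(C(F)(F)F)cc3)nc3ccccc23)cc1` is not yet measured. It differs from compound 3 as methyl in place of trifluoromethyl on an aromatic carbon. The same kind of change, (methyl in place of trifluoromethyl on an aromatic carbon), occurs once before among these compounds and gave an at least 1.3-fold lower number from compound 1 to compound 2 (0.12 log units; that floor lies within the scatter), a floor that arises because compound 1 sits at the limit of > 50000 nM in this assay, at which 1 of the 3 values shown sits. The surroundings differ: there the group sits ortho to a large group, whereas in compound 4 it sits para to a large group. Resting on that single bounded step, compound 4 is expected to stay near compound 3, with an estimated step of a 1.6-fold higher number from compound 3 to compound 4 (0.20 log units; within the scatter). Compound 4 is thus estimated at 8000 nM, expected between 2500 nM and 25000 nM.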

Compound 4, half-maximal inhibitory concentration: > 50000 nM
Compound 4: no number, only a limit (the forecaster's own chance of this, stated with the estimate: 10%); middle value at least 6.2-fold (0.79 log units) from the limit.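

In this assay, on the core bearing 4-(trifluoromethyl)phenyl, methyl in place of trifluoromethyl gives an at least 9.8-fold higher number from compound 3 to compound 4 (0.99 log units; beyond the scatter). This change therefore does not carry over unchanged from one core to the other: the same change on two cores in this assay, an at least 1.3-fold lower number (0.12 log units; that floor lies within the scatter) from compound 1 to compound 2 and an at least 9.8-fold higher number (0.99 log units; beyond the scatter) from compound 3 to compound 4, at least 13-fold (1.11 log units) apart, beyond the scatter of two such steps

Going by these compounds, the true size remains unknown for an at least 1.3-fold higher number from compound 2 to compound 4 (0.12 log units; that floor lies within the scatter), which is only a floor. The step between compound 1 and compound 4 cannot be read, with these compounds resting on a limit rather than a number: the limit of > 50000 nM in this assay, at which 2 of the 4 values shown sit.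

The compounds shown leave open how a chlorine atom, a methoxy group or a carboxylic acid would fare in that place on the phenyl ring. They also leave open how the methyl change would behave on any third core.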